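An Oxazole in Place of a Methylpyrazole on a Fused Core

A few compounds are considered here, and "the series" means these few. Any claim that something is new, unique, unknown or untested is made for them only; others in the source may bear on it.

Compound 1 `Cn1ccc(-c2cccc3c2CCC3c2ncc[nH]2)n1` was tested in a functional assay on CHO cells for agonist activity at Alpha-1B adrenergic receptor (Homo sapiens), read by FLIPR and calcium flux; a higher number here means that more compound is needed for the effect, a lower number that less compound is needed. In this assay compound 1 gives > 10000 nM, which is a limit of the assay and not a number. Compound 2 `CCS(=O)(=O)Nc1cccc(Cc2c[nH]cn2)c1` gives > 10000 nM in this assay, again a limit. Compound 3 `CS(=O)(=O)Nc1cccc2c1CCCC2c1ncc[nH]1` gives > 10000 nM; > 10000 nM; > 10000 nM (3 entries) in this assay, a limit in each of its three entries. Compound 1 therefore stands on no number at all: every value shown for it and its companions rests at the limit of > 10000 nM in this assay, at which 2 of the 3 values shown sit. Among the compounds with values here, no step between two measured compounds can be drawn, since none of them differs from another in just one place.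

Compound 4 `c1cc(-c2ncco2)c2c(c1)C(c1ncc[nH]1)CC2` is not yet measured in this assay. It differs from compound 1 by 1,3-oxazol-2-yl in place of 1-methyl-1H-pyrazol-3-yl on an aromatic carbon. Because nothing measured here rises above (the limit of > 10000 nM in this assay, at which 2 of the 3 values shown sit), the step expected is a step that the limit leaves unreadable from compound 1 to compound 4, meaning no change beyond the scatter is expected. Compound 4 is accordingly expected to give about 15000 nM in this assay, with a range from 3000 nM to 60000 nM, and is most likely to be reported only as a limit once more.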

Compound 4, half-maximal effective concentration: > 10000 nM
Compound 4: only a limit was reported (the forecaster's own chance of this, stated with the estimate: 75%); the middle value does not contradict the limit.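

In this assay compound 4 gives > 10000 nM, which is a limit of the assay and not a number. Within the data shown here, compound 1 also stands at a limit, so no step between compound 1 and compound 4 can be read. The compounds shown leave open how 1,3-oxazol-2-yl and 1-methyl-1H-pyrazol-3-yl compare on the shared core, and whether any of these compounds reaches a number in this assay: the limit of > 10000 nM in this assay, at which 3 of the 4 values shown sit.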